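Methoxy Addition on a Prostaglandin D2 Receptor Antagonist Core

This account rests on a few compounds, and the source may have more. Where it says the series, first, only, none or still open, it means among the compounds named here.

Three compounds have so far been measured in a functional assay on CHO.K1 cells for antagonist activity at prostaglandin D2 receptor 2 (Homo sapiens), read by GTPgammaS binding, with a stated time of 1 h; on this read-out higher numbers stand for weaker inhibition and lower numbers for stronger inhibition:
compound 1 `Cc1c(Cc2ccccc2S(=O)(=O)c2ccc(F)cc2)c2c(n1CC(=O)O)CCNC2=O` gives 3.3 nM
compound 2 `COc1ccc(S(=O)(=O)c2ccc(F)cc2)c(Cc2c3c(n(CC(=O)O)c2C)CCNC3=O)c1` gives 7.1 nM
compound 3 `Cc1c(Cc2ccccc2S(=O)(=O)c2ccc(F)cc2)c2c(n1CC(=O)O)CC(C)(C)NC2=O` gives 5 nM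

Compound 4 `COc1ccc(S(=O)(=O)c2ccc(F)cc2)c(Cc2c3c(n(CC(=O)O)c2C)CC(C)(C)NC3=O)c1` has not yet been measured. Compound 2 arises from compound 1 by the change (methoxy in place of hydrogen on an aromatic carbon), and in this assay that change produced a 2.2-fold higher number from compound 1 to compound 2 (0.33 log units; beyond the scatter). Compound 4 arises from compound 3 by methoxy in place of hydrogen on an aromatic carbon, which is the same change at the same place. The difference between the core of compound 1 and the core of compound 3 is not broken down here. In this assay compound 3 gives 5 nM, a value that lies within the scatter of both compound 1 and compound 2, so no order among these three compounds can be stated.

The expectation for compound 4 rests on one earlier instance of the change. Compound 4 is expected to show a step of a 2.2-fold higher number from compound 3 to compound 4 (0.34 log units; beyond the scatter) in this assay because the earlier instance gave a 2.2-fold higher number from compound 1 to compound 2 (0.33 log units; beyond the scatter). Among the compounds with values here, with only a single precedent the step may be somewhat larger or smaller than that, and the range allows for this. Compound 4 is therefore estimated at 11 nM in this assay, with an expected range from 5 nM to 25 nM.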

Compound 4, half-maximal inhibitory concentration: 5 nM
Beside the measured number, compound 4's estimate is 2.2-fold (0.34 log units) above it; low and high end bracket the measured number.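

In this assay, methoxy in place of hydrogen on the aromatic carbon para to the (4-fluorophenyl)sulfonyl group gave no change at the digits printed from compound 3 to compound 4 (within the scatter). Set beside the earlier instance of the same change, the new step cannot be told apart from it: the same change on two cores in this assay, a 2.2-fold higher number (0.33 log units; beyond the scatter) from compound 1 to compound 2 and no change at the digits printed (within the scatter) from compound 3 to compound 4, 2.2-fold (0.33 log units) apart, within the scatter of two such steps. This shows that, on the core of compound 1 and the core of compound 3, the change gives steps that do not differ measurably from each other, but two instances cannot establish one common size for the step, cannot settle whether that size is modest or nil, and give no reason for the reading on either core.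

As far as these compounds go, all four compounds carry either hydrogen or methoxy at this place, so it remains open how an ethoxy group, a chlorine atom or a hydroxyl group there would read in this assay. All four also keep the carboxylic acid and the (4-fluorophenyl)sulfonyl group, which leaves open whether the methoxy step would hold up with an ester or a tetrazole in place of that carboxylic acid.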